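Working notes: from compound 3 to compound 4

The source may hold more compounds than are shown below. What is called first, only, known or untested is meant among the compounds shown, and "the series" means these compounds.

- compound 1 `CC(C)c1nc2ccccn2c1C(=O)NCc1ccc(-c2ccccc2)cc1` gives 0.527 h
- compound 2 `CCc1nc2ccc(Cl)cn2c1C(=O)NCc1ccc(-c2ccccc2Cl)cc1` gives 0.648 h
- compound 3 `CCc1nc2cc(Cl)ccn2c1C(=O)NCc1ccc(-c2ccc[nH]2)cc1` gives > 2 h

In an ADME assay (liver) for metabolic stability, with Liver microsome (Homo sapiens) as the target, using microsomes (on this read-out higher numbers stand for a longer-lived compound and lower numbers for a shorter-lived compound), compound 3 stands at > 2 h as a limit and not a number. Compound 4 `CCc1nc2cc(Cl)ccn2c1C(=O)NCc1ccc(N2CCN(C(C)C)CC2)cc1` has 4-isopropylpiperazin-1-yl in place of 1H-pyrrol-2-yl on an aromatic carbon, para to a large group 4-isopropylpiperazin-1-yl in place of 1H-pyrrol-2-yl on an aromatic carbon as the whole change. For the measured compounds named here, no measured step covers this change. Going by the values given here, the expectation rests on compound 1 at 0.527 h and compound 2 at 0.648 h as the only numbers available, and these two lie within the scatter of each other. A shortening is expected, estimated as the step of an at least 2.8-fold lower number from compound 3 to compound 4 (0.45 log units; beyond the scatter) in this assay and uncertain in size. In this assay compound 4 is estimated at 0.7 h with an expected range from 0.25 h to 2 h.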

Compound 4, half-life: > 2 h
Compound 4 gave a limit, no number (the forecaster's own chance of this, stated with the estimate: 12%); middle value at least 2.8-fold (0.45 log units) from the limit.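

No step can be read between compound 3 and compound 4, since both stand at the same limit and neither gives a number: the limit of > 2 h in this assay, at which 2 of the 4 values shown sit.

Going by these compounds, whether 4-isopropylpiperazin-1-yl in place of 1H-pyrrol-2-yl changes the half-life at all, and by how much, stays open.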